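This account rests on a few compounds, and the source may have more. Where it says the series, first, only, none or still open, it means among the compounds named here.

Measured compounds:
- compound 1, `NCc1cn(CC(=O)Nc2sc3c(c2C(N)=O)CCCC3)nc1C(F)(F)F`, giving 794 nM in an assay on isolated protein with metabotropic glutamate receptor 1 (Homo sapiens) as the target; a lower number here means that less compound is needed, a higher number that more compound is needed for the effect
- compound 2, `CCNCc1cn(CC(=O)Nc2sc3c(c2C(N)=O)CCCC3)nc1C(C)(C)C`, giving 794 nM in this assay

Of the compounds shown here, two on the shared core have been measured. In this assay compound 1 gives 794 nM, and compound 2 gives 794 nM in the same assay. The two values stand level at the digits recorded; the two structures differ in more than one place, so nothing beyond that sameness can be read from the pair.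

Compound 3, `COCCNCc1cn(CC(=O)Nc2sc3c(c2C(N)=O)CCCC3)nc1C(F)(F)F`, has not yet been measured in this assay. It departs from compound 1 by a single change: 2-methoxyethyl in place of hydrogen on an amine nitrogen. The nitrogen in question already carries a saturated chain carbon, and the incoming group brings one hydrogen-bond acceptor and no ring.

Among the compounds with values here, no step between two measured compounds is available to calibrate this change. The level pair of compound 1 and compound 2 suggests that substitution on this amine nitrogen is tolerated without a large shift. Compound 3 is therefore estimated to lie close to compound 1, with an expected step of a 1.1-fold lower number from compound 1 to compound 3 (0.05 log units; within the scatter) that stays within the usual scatter. The estimate for compound 3 is 700 nM, with a range from 250 nM to 2000 nM.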

Compound 3, half-maximal effective concentration: 1580 nM
Compound 3: middle estimate off by 2.3-fold (0.35 log units), on the low side; low and high end bracket the measured number.
By their numbers in this assay, from the lowest: compounds 1, 2 and 3 (each within the scatter of the next).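

In this assay, within the data shown here, this gives the first step that can be read at this amine nitrogen on its own: a 2.0-fold higher number from compound 1 to compound 3 (0.30 log units; within the scatter). Compounds 1 and 2 differ in more than one place, so their level values could not isolate this position, whereas this single change shows that 2-methoxyethyl in place of hydrogen, on an amine nitrogen whose other neighbour is a saturated chain carbon, leaves the number within the scatter of repeated measurements. Nothing available explains the size of this step or says what lies behind it.

The compounds shown leave open whether the oxygen of the 2-methoxyethyl group plays any part, which a plain butyl chain on the same nitrogen would help to separate, and how a larger group such as a benzyl or a chain ending in a carboxylic acid would read there. They also leave open whether the same change would give a similar step on compound 2, which differs from compound 1 in more than one place.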